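The source may hold more compounds than are shown below. What is called first, only, known or untested is meant among the compounds shown, and "the series" means these compounds.

Measured so far:
- compound 1 `O=C(Nc1cccc(-c2cnc3c(NC(=O)c4cc(Cl)cc(Cl)c4)nccn23)c1)c1ccc(Cl)c(C(F)(F)F)c1`: 3230 nM
- compound 2 `O=C(Nc1cccc(-c2cnc3c(NC(=O)c4cc(Cl)cc(Cl)c4)nccn23)c1)Nc1ccc(F)cc1F`: 2610 nM

In a functional assay on A549 cells (Homo sapiens) for antiproliferative activity, read by CellTiter-Glo, with a stated time of 72 h (on this read-out lower numbers stand for stronger inhibition and higher numbers for weaker inhibition), compound 1 gives 3230 nM and compound 2 gives 2610 nM; the two numbers sit within the scatter of each other, so compound 2 stands level with compound 1 on the numbers shown. Among the compounds with values here, the one step known, a 1.2-fold lower number from compound 1 to compound 2 (0.09 log units; within the scatter), exchanges an amide for a urea with a different aryl group at the same time and reads as no change.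

Compound 3 `O=C(Nc1cccc(-c2cnc3c(NC(=O)c4cc(Cl)cc(Cl)c4)nccn23)c1)Nc1ccc(Cl)c(C(F)(F)F)c1` keeps the urea of compound 2 and returns the aryl group of compound 1: 4-chloro-3-(trifluoromethyl)phenyl in place of 2,4-difluorophenyl on an amide-type nitrogen. Within the data shown here, no measured step isolates this aryl exchange on a urea; the only step that bears on it at all is the one from compound 1 to compound 2, which was within the scatter. The expectation is therefore a step of a 1.0-fold lower number from compound 2 to compound 3 (0.00 log units; within the scatter), no movement beyond the scatter, and compound 3 is estimated at 2600 nM in this assay, with a range of 900 nM to 7500 nM.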

Compound 3, half-maximal inhibitory concentration: 8440 nM
Compound 3: the middle estimate sits 3.2-fold (0.51 log units) below what was measured; measured number outside the range, above it.
By their numbers in this assay, from the lowest: compounds 2 and 1 (each within the scatter of the next); then compound 3.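

On the urea, the aryl group on the amide-type nitrogen does register in this assay, with a 3.2-fold higher number from compound 2 to compound 3 (0.51 log units; beyond the scatter) as 4-chloro-3-(trifluoromethyl)phenyl replaces 2,4-difluorophenyl. With that aryl group held constant, the urea of compound 3 also separates from the amide of compound 1, with a 2.6-fold higher number from compound 1 to compound 3 (0.42 log units; beyond the scatter), so the level result for compound 1 and compound 2, where both features changed together, did not mean that neither feature matters. No evidence here bears on why either step occurs.

On these data alone, whether 2,4-difluorophenyl on the amide would match its urea counterpart remains open. Also open, as far as these compounds go, is whether a urea aryl group carrying a morpholine or a carboxylic acid would give a number clearly below that of compound 2.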